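The compounds below may be only part of what the source reports. "The series", "measured", "known", "first", "only" and "open" are said of these compounds alone.

Three compounds were measured in a functional assay on A549 cells (Homo sapiens) for antiproliferative activity, read by MTT assay, with a stated time of 48 h; on this read-out lower numbers stand for stronger inhibition and higher numbers for weaker inhibition:

Compound 1, `CNCC(=O)Nc1cc(OC)ccc1C(=O)c1cc(OC)c(OC)c(OC)c1`: 610 nM
Compound 2, `CCNCC(=O)Nc1cc(OC)ccc1C(=O)c1cc(OC)c(OC)c(OC)c1`: 750 nM
Compound 3, `C=C(c1ccc(OC)cc1NC(=O)CNC)c1ccc(OC)c2c1OC(C)(C)C=C2`: 150 nM

Compound 1 and compound 2 share a core and differ in one place: methyl in place of hydrogen on a saturated chain carbon bound to an amine nitrogen. In this assay this change gave a 1.2-fold higher number from compound 1 to compound 2 (0.09 log units; within the scatter), so the two values cannot be told apart within the usual scatter of this read-out.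

Compound 3 is built on a different core, and the difference between the two cores is not broken down here. Its value in this assay is the lowest of the three, and the gaps to compound 1 and to compound 2 are both beyond the scatter, so compound 3 stands as the most potent of the measured set.

Compound 4, `C=C(c1ccc(OC)cc1NC(=O)CNCC)c1ccc(OC)c2c1OC(C)(C)C=C2`, has not yet been measured. It relates to compound 3 in the same way that compound 2 relates to compound 1: methyl in place of hydrogen on a saturated chain carbon bound to an amine nitrogen. The place of the change is described in the same words in both pairs, so it is the same change carried onto the core of compound 3.

Going by the values given here, the one precedent is the step from compound 1 to compound 2, a 1.2-fold higher number from compound 1 to compound 2 (0.09 log units; within the scatter), which lies within the scatter. On that basis compound 4 is expected to give a 1.2-fold higher number from compound 3 to compound 4 (0.08 log units; within the scatter) in this assay, with nothing in the measured compounds pointing to a larger move in either direction. Compound 4 is therefore estimated at 180 nM in this assay, with a likely range from 90 nM to 360 nM.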

Compound 4, half-maximal inhibitory concentration: 970 nM
The estimate for compound 4 lay 5.4-fold (0.73 log units) below the measured number, and the stated range ends below it.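

In this assay the change from methylamino to ethylamino gave a 6.5-fold higher number from compound 3 to compound 4 (0.81 log units; beyond the scatter) and so stood clear of the scatter on this core. The change therefore does not carry over at one fixed size between the two cores: the same change on two cores in this assay, a 1.2-fold higher number (0.09 log units; within the scatter) from compound 1 to compound 2 and a 6.5-fold higher number (0.81 log units; beyond the scatter) from compound 3 to compound 4, 5.3-fold (0.72 log units) apart, beyond the scatter of two such steps. This shows that, in this series, the size of the step on one core is no safe guide to its size on the other, but with a single pair on each core it does not show what in the cores sets the two steps apart, nor which of the two sizes would be the usual one on any further core.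

The compounds shown carry only methylamino and ethylamino at this place, so they leave open how a longer chain such as propylamino, a branched chain such as isopropylamino, a primary amine or a cyclic amine such as pyrrolidine would behave on either core. They also leave open whether such groups would give similar steps on the two cores or would part as the ethylamino step does here.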